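Furan for pyrimidine on the shared core of compound 1

This account rests on a few compounds, and the source may have more. Where it says the series, first, only, none or still open, it means among the compounds named here.

Two compounds of this set have numbers in an assay on L cells for inhibition of Protein-serine O-palmitoleoyltransferase porcupine (Mus musculus), read by reporter gene assay, with a stated time of 24 h; on this read-out higher numbers stand for an effect only at larger amounts of compound and lower numbers for an effect already at smaller amounts. Compound 1 `O=C(CSc1nc2c(c(=O)n1-c1ccccc1)SCC2)Nc1ccc(-c2cncnc2)cn1` gives 5.5 nM in this assay, the lowest of the two numbers. Compound 2 `O=C(CNC(=O)c1nn(-c2ccccc2)c(=O)c2ccccc12)Nc1nc2ccc(Cl)cc2s1`, built on a different core, gives 30 nM in this assay; its number stands above that of compound 1, and the gap lies beyond the scatter. Among the measured compounds shown here, no pair of measured compounds differs in one place only, so no single-point step has been measured in this set.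

Compound 3 `O=C(CSc1nc2c(c(=O)n1-c1ccccc1)SCC2)Nc1ccc(-c2ccoc2)cn1` is not yet measured in this assay. It differs from compound 1 in one place: furan-3-yl in place of pyrimidin-5-yl on an aromatic carbon. For the measured compounds named here, nothing among the measured compounds shows what this change does in this assay; only the change itself and the number of compound 1, 5.5 nM, are known. The expected outcome is a modest step toward higher numbers, close to the edge of the scatter rather than clearly beyond it. For compound 3 the estimate in this assay is 15 nM, with a range from 4 nM to 60 nM. The step that this estimate means, a 2.7-fold higher number from compound 1 to compound 3 (0.44 log units; beyond the scatter), is expected to be small.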

Compound 3, half-maximal effective concentration: 1.5 nM
Estimate against measurement, compound 3: 10-fold (1.00 log units) above; measured number outside the range, below it.
By their numbers in this assay, from the lowest: compound 3; then compound 1; then compound 2.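

In this assay, furan-3-yl in place of pyrimidin-5-yl on an aromatic carbon gives a 3.7-fold lower number from compound 1 to compound 3 (0.56 log units; beyond the scatter). Among the compounds shown here, this is the first single-point step in the set, and it shows that the position, two atoms from the ring nitrogen and para to a large group, responds to a change of its aromatic group, with the five-membered aromatic ring with 1 hetero atom giving the lower number of the pair and the two nitrogens of pyrimidin-5-yl not required for a number of this order. No measurement on hand bears on the reason for this step.

Ring size and hetero atoms change together in this one step, so their shares stay unresolved: thiophen-3-yl or pyridin-3-yl on the same aromatic carbon would help to separate them. Also open, on these data alone, are whether an aromatic ring is required here at all, as against an amine, a carboxylic acid or a longer chain on that carbon, and whether the same change would give a step of similar direction on a core other than that of compound 1.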